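This account rests on a few compounds, and the source may have more. Where it says the series, first, only, none or still open, it means among the compounds named here.

Compound 1 `C[C@](N)(COP(=O)(O)O)C(=O)Nc1ccc(OCCCCCc2ccccc2)cc1` carries an amino acid phosphate head joined through an amide to an aromatic ring, from which an ether chain runs out to a terminal phenyl group. In an assay on isolated protein for displacement of a labelled ligand from sphingosine 1-phosphate receptor 5 (Homo sapiens) (on this read-out lower numbers stand for stronger inhibition and higher numbers for weaker inhibition), compound 1 gives 2.9 nM. Compound 2 `COc1ccc(CCCCOc2ccc(NC(=O)[C@@](C)(N)COP(=O)(O)O)cc2)cc1` keeps the same head, amide and ether chain, but its chain ends in an aromatic ring that carries a methoxy group; in this assay compound 2 gives "not determined" (no result reported), so it stands nowhere on the numbers shown. Compound 3 `C[C@](N)(COP(=O)(O)O)C(=O)Nc1ccc(OCCCCc2ccc(-c3ccccc3)cc2)cc1` differs from compound 2 by phenyl in place of methoxy on an aromatic carbon. Going by the values given here, no measured pair mirrors this change, so the size of the step in this assay cannot be read from the data; a shift in either direction no larger than the usual scatter seems as likely as a real one. Compound 3 is expected to give about 5 nM in this assay, within a range from 1 nM to 30 nM, because compound 1 gives 2.9 nM with a chain that also ends in an aromatic ring.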

Compound 3, half-maximal inhibitory concentration: 99.8 nM
Beside the measured number, compound 3's estimate is 20-fold (1.30 log units) below it; measured number outside the range, above it.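

Going by these compounds alone, compound 2 has no reported result, so no step from compound 2 to compound 3 can be read. The compounds shown leave open what replacing methoxy with phenyl does on this read-out. No supporting evidence bears on the value of compound 3.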